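This account rests on a few compounds, and the source may have more. Where it says the series, first, only, none or still open, it means among the compounds named here.

Values in an ADME assay on MT4 cells (Homo sapiens) for cytotoxicity (on this read-out lower numbers stand for higher toxicity in this test and higher numbers for lower toxicity in this test), so far:
Compound 1 `Fc1ccc(NC(=S)Nc2cccc(C(F)(F)F)c2)cc1` gives 31000 nM 
Compound 2 `C=C(C)CNC(=S)Nc1cccc(C(F)(F)F)c1` gives 43000 nM 

These two values lie within the scatter of each other, so compound 2 stands level with compound 1 on the numbers shown. Compound 3 `CSCCCNC(=S)Nc1cccc(C(F)(F)F)c1` has not yet been measured. It keeps the rest of compound 2 and alters only the end of the chain, with 2-(methylsulfanyl)ethyl in place of 1-methylethenyl on a saturated chain carbon bound to an amide-type nitrogen. Among the compounds with values here, only one measured step bears on this change. That step, a 1.4-fold higher number from compound 1 to compound 2 (0.14 log units; within the scatter), put 2-methylprop-2-en-1-yl in place of 4-fluorophenyl on an amide-type nitrogen. With this single step as a guide, no shift beyond the scatter is expected in this assay, and the estimated step is a 1.1-fold lower number from compound 2 to compound 3 (0.03 log units; within the scatter). For compound 3 the expected value is 40000 nM, with an estimated range from 18000 nM to 85000 nM.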

Compound 3, half-maximal cytotoxic concentration: 43000 nM
Compound 3: the middle estimate sits 1.1-fold (0.03 log units) below what was measured, within the range that was stated.
By their numbers in this assay, from the lowest: compounds 1, 2 and 3 (each within the scatter of the next).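

In this assay, putting 2-(methylsulfanyl)ethyl in place of 1-methylethenyl on a saturated chain carbon bound to an amide-type nitrogen gives no change at the digits printed from compound 2 to compound 3 (within the scatter), so a chain carrying a sulfur and a hydrogen-bond acceptor stands level with one carrying a double bond. Replacing 4-fluorophenyl with 3-(methylsulfanyl)propyl on an amide-type nitrogen likewise gives a 1.4-fold higher number from compound 1 to compound 3 (0.14 log units; within the scatter), which means that all three compounds shown, with their different groups at this position, remain within the scatter of each other. No measurement shown here explains this level result.

From the compounds shown here alone, whether an amine, a carboxylic acid or a much longer chain at this position would move the number beyond the scatter remains open. So does the effect of any change to the shared core, which stays the same in all three compounds.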